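Ethyl ester in place of the amide on a nucleoside urea

This account rests on a few compounds, and the source may have more. Where it says the series, first, only, none or still open, it means among the compounds named here.

Of the compounds shown here, two sharing one core have been measured in a functional assay on LOX IMVI cells (Homo sapiens) for antiproliferative activity; a lower number here means a stronger inhibitor of growth, a higher number a weaker inhibitor of growth. Compound 1 `CCOC(=O)C[C@H]1[C@@H](O[Si](C)(C)C(C)(C)C)[C@H](n2cnc3c(NC(=O)Nc4ccccc4)ncnc32)O[C@@H]1COC(=O)NC` gives 7.78 nM in this assay. Compound 2 `CNC(=O)NC[C@H]1O[C@@H](n2cnc3c(NC(=O)Nc4ccccc4)ncnc32)[C@H](O[Si](C)(C)C(C)(C)C)[C@@H]1CC(=O)N(C)OC` gives 7.3 nM in this assay, a number that sits within the scatter of that of compound 1. Compound 3 `CCOC(=O)C[C@H]1[C@@H](O[Si](C)(C)C(C)(C)C)[C@H](n2cnc3c(NC(=O)Nc4ccccc4)ncnc32)O[C@@H]1CNC(=O)NC` has not yet been measured. It differs from compound 2 by ethoxy in place of methoxy(methyl)amino on a carbonyl carbon. Since compound 1 already carries an ethoxy on that carbonyl carbon and gives 7.78 nM, no step beyond the scatter is expected from compound 2 to compound 3, and compound 3 is estimated at 8 nM, between 4 nM and 16 nM, meaning a step of a 1.1-fold higher number from compound 2 to compound 3 (0.04 log units; within the scatter).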

Compound 3, concentration for 50% growth inhibition: 5.46 nM
For compound 3 the middle estimate is 1.5-fold (0.17 log units) above the measured one, and the stated range covers the measured number.
By their numbers in this assay, from the lowest: compounds 3, 2 and 1 (each within the scatter of the next).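

In this assay, ethoxy in place of methoxy(methyl)amino on a carbonyl carbon gives a 1.3-fold lower number from compound 2 to compound 3 (0.13 log units; within the scatter), so with the (methylcarbamoyl)amino group held constant, this exchange produces no step beyond the scatter. Compound 3 also gives a one-place comparison at the saturated chain carbon bound to a saturated ring carbon: (methylcarbamoyl)amino in place of (methylcarbamoyl)oxy gives a 1.4-fold lower number from compound 1 to compound 3 (0.15 log units; within the scatter), again within the scatter. No other evidence bears on these results. As far as these compounds go, whether a carboxylic acid or a butyl ester on that carbonyl carbon would also stay within the scatter remains open.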